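Removing one chloro from the bis-benzyl core of compound 1

This account rests on a few compounds, and the source may have more. Where it says the series, first, only, none or still open, it means among the compounds named here.

Compound 1 `O=C1c2ccccc2N(Cc2ccccc2Cl)S(=O)(=O)N1Cc1ccccc1Cl` carries two 2-chlorobenzyl groups on the shared core. As far as these compounds go, in a functional assay on HEL cells (Homo sapiens) (on this read-out lower numbers stand for higher toxicity in this test and higher numbers for lower toxicity in this test), compound 1 gives only a limit of the assay, > 20000 nM, so its exact standing on the numbers is unknown. Compound 2 `O=C1c2ccccc2N(Cc2ccccc2Cl)S(=O)(=O)N1COCc1ccccc1` gives 200000 nM in this assay, and compound 3 `O=C1c2ccccc2N(Cc2ccc(Cl)c(Cl)c2)S(=O)(=O)N1Cc1ccccc1` gives 200000 nM, two values that sit together. For the measured compounds named here, the step that the limit leaves unreadable from compound 1 to compound 2 cannot be sized because of the limit of > 20000 nM in this assay, at which 1 of the 3 values shown sits; no other measured step exists that touches the change considered here.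

Compound 4 `O=C1c2ccccc2N(Cc2ccccc2)S(=O)(=O)N1Cc1ccccc1Cl` differs from compound 1 by hydrogen in place of chloro on an aromatic carbon. With compound 1 known only as a limit, the expected size of a step that the limit leaves unreadable from compound 1 to compound 4 cannot be anchored to a measured step, and the three compounds seen so far all sit at the low-toxicity end of this assay; the expectation is therefore that compound 4 likewise shows little toxicity, possibly again as a limit. Compound 4 is estimated at 100000 nM, within a range from 20000 nM to 200000 nM.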

Compound 4, minimum cytotoxic concentration: 200000 nM
Compound 4: middle estimate off by 2.0-fold (0.30 log units), on the low side; low and high end bracket the measured number.
By their numbers in this assay, from the lowest: compounds 2, 3 and 4 (each within the scatter of the next).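

No new step can be read from compound 1 to compound 4 because compound 1 stands only as a limit: the limit of > 20000 nM in this assay, at which 1 of the 4 values shown sits.

The compounds shown leave open whether hydrogen in place of chloro on an aromatic carbon shifts the reading in this assay at all.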